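Replacing the pyrrole-bearing aromatic group of compound 3

The source may report more compounds than this note shows. Statements on the series, on what has been measured and on what is new or still open speak of the compounds shown alone.

For the measured compounds named here, in an ADME assay on Caco-2 cells (Homo sapiens) for permeability, in the apical to basolateral direction (on this read-out lower numbers stand for lower permeability and higher numbers for higher permeability), compound 3 `Cn1cncc1CN1CC(N(Cc2cccc(-n3cccc3)c2)S(=O)(=O)c2ccccn2)Cc2cc(C#N)ccc21` gives 2.3 10^-6 cm/s, the highest of the three numbers so far. Compound 1 `Cn1cncc1CN1CC(N(CC2CCN(C(=O)C3CCCC3)CC2)S(=O)(=O)c2ccccn2)Cc2cc(C#N)ccc21` gives 0.5 10^-6 cm/s, and compound 2 `CC(C)NC(=O)N1CCC(CN(C2Cc3cc(C#N)ccc3N(Cc3cncn3C)C2)S(=O)(=O)c2ccccn2)CC1` gives 0.6 10^-6 cm/s. Compound 4 `C=C(C)C(=O)N1CCC(CN(C2Cc3cc(C#N)ccc3N(Cc3cncn3C)C2)S(=O)(=O)c2ccccn2)CC1` carries 1-((1-methylethenyl)carbonyl)piperidin-4-yl in place of 3-(1H-pyrrol-1-yl)phenyl on a saturated chain carbon bound to a sulfonamide nitrogen. Compounds 1, 2 and 4 all hold a piperidine with a carbonyl group. Changing what sits on that carbonyl gave a 1.2-fold higher number from compound 1 to compound 2 (0.08 log units; within the scatter). Leaving that piperidine type at the same place gave a 3.8-fold higher number from compound 2 to compound 3 (0.58 log units; beyond the scatter), so a near reversal seems likely. The expected change is a drop beyond the scatter, a 3.3-fold lower number from compound 3 to compound 4 (0.52 log units; beyond the scatter). Compound 4 is estimated at 0.7 10^-6 cm/s, with an expected range of 0.3 10^-6 cm/s to 1.5 10^-6 cm/s.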

Compound 4, apparent permeability: 0.5 10^-6 cm/s
Estimate against measurement, compound 4: 1.4-fold (0.15 log units) above, and the stated range covers the measured number.
By their numbers in this assay, from the lowest: compounds 1, 4 and 2 (each within the scatter of the next); then compound 3.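

Putting 1-methylethenyl on the carbonyl carbon in this assay gives a 1.2-fold lower number from compound 2 to compound 4 (0.08 log units; within the scatter) against isopropylamino and no change at the digits printed from compound 1 to compound 4 (within the scatter) against cyclopentyl, so three different groups on that carbonyl read alike. The larger difference lies in the whole group on a saturated chain carbon bound to a sulfonamide nitrogen, with a 4.6-fold lower number from compound 3 to compound 4 (0.66 log units; beyond the scatter) when the piperidine returns. No measurement here explains that difference.

Still open, on these data alone, is whether a plain phenyl without the pyrrole, or a piperidine with only a methyl on its nitrogen, would read like compound 3 or like compound 4.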